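The compounds below may be only part of what the source reports. "The series", "measured", "known", "first", "only" and "open" are said of these compounds alone.

Compound 1, `COc1cc2c(cc1OC)CN(CCCCNC(=O)c1cn(-c3ccccc3OCCF)nn1)CC2`, is the weaker of the two measured compounds: in an assay on membranes from brain for displacement of a labelled ligand from Sigma non-opioid intracellular receptor 1 (Cavia porcellus), read by scintillation counting, with a stated time of 90 min (on this read-out lower numbers stand for stronger inhibition and higher numbers for weaker inhibition), compound 1 gives 17100 nM. Compound 2, `COc1cc2c(cc1OC)CN(CCCCNC(=O)c1cn(Cc3ccccc3)nn1)CC2`, carries a benzyl on the aromatic nitrogen instead of the 2-(2-fluoroethoxy)phenyl; in this assay compound 2 gives 4480 nM. Among the measured compounds shown here, the step from one to the other, a 3.8-fold lower number from compound 1 to compound 2 (0.58 log units; beyond the scatter), is a modest but real improvement, and it leaves compound 2 with the lower of the two numbers so far.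

Compound 3, `COc1cc2c(cc1OC)CN(CCCCNC(=O)c1cn(Cc3cccc(O)c3)nn1)CC2`, is the next in line. Relative to compound 2 the change is hydroxy in place of hydrogen on an aromatic carbon. For the measured compounds named here, no measured step touches this kind of change: the only step available swaps the whole group on the aromatic nitrogen, whereas here the benzyl stays and only gains a hydroxy. Without a precedent for a substituent on that ring, the safest expectation is a step no larger than the scatter in either direction. The step from compound 2 to compound 3 is therefore expected to be a 1.3-fold lower number from compound 2 to compound 3 (0.11 log units; within the scatter), and compound 3 is estimated at 3500 nM, within a range from 1200 nM to 10000 nM.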

Compound 3, inhibition constant: 8080 nM
Beside the measured number, compound 3's estimate is 2.3-fold (0.36 log units) below it; low and high end bracket the measured number.
By their numbers in this assay, from the lowest: compounds 2 and 3 (each within the scatter of the next); then compound 1.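

In this assay, the first substituent on the benzyl ring gives a 1.8-fold higher number from compound 2 to compound 3 (0.26 log units; within the scatter), so at this place a hydroxy in place of hydrogen cannot be told apart from the unsubstituted ring, and the added oxygen, with its hydrogen-bond donor and acceptor, produces no readable change. The comparison with the aryl group shows that the advantage over compound 1 survives this change: 3-hydroxybenzyl in place of 2-(2-fluoroethoxy)phenyl gives a 2.1-fold lower number from compound 1 to compound 3 (0.33 log units; beyond the scatter), a modest step beyond the scatter, so both benzyl-type compounds now stand apart from compound 1. Nothing available explains why the hydroxy leaves the number within the scatter.

The compounds shown leave open whether this place on the ring is insensitive to substitution in general or only to a hydroxy, since a single small group says little about an amine, a carboxylic acid or a methoxy there. They also leave open whether a longer chain between the aromatic nitrogen and the phenyl ring would take the number further from that of compound 1 than benzyl does.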